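The source may report more compounds than this note shows. Statements on the series, on what has been measured and on what is new or still open speak of the compounds shown alone.

In an ADME assay for pharmacokinetics, in simulated intestinal fluid (a lower number here means that the compound disappears faster, a higher number that the compound lasts longer), compound 1 (`CCOC(=O)/C=C/c1ccc(NC(=O)C2(NC(=O)c3ccc4c(C5CCCC5)c(-c5ncc(Cl)cn5)n(C)c4c3)CCC2)cc1OCC`) gives > 5 h, which is a limit of the assay. Compound 2 (`CCCOC(=O)/C=C/c1ccc(NC(=O)C2(NC(=O)c3ccc4c(C5CCCC5)c(-c5ncc(Cl)cn5)n(C)c4c3)CCC2)cc1OCC`) gives > 5 h, also a limit. Compound 2 therefore stands at the limit of > 5 h in this assay, at which 2 of the 2 values shown sit. Going by the values given here, the one measured change, a step that the two limits leave unreadable from compound 1 to compound 2, offers no size to carry forward. Compound 3 (`CCOc1cc(NC(=O)C2(NC(=O)c3ccc4c(C5CCCC5)c(-c5ncc(Cl)cn5)n(C)c4c3)CCC2)ccc1/C=C/C(=O)OCC(Cl)(Cl)Cl`) differs from compound 2 as follows: trichloromethyl in place of ethyl on a saturated chain carbon bound to an oxygen next to a carbonyl group. With no readable step to build on, the expected change is none beyond the scatter, in neither direction: a step that the limit leaves unreadable from compound 2 to compound 3. The half-life expected for compound 3 is 6 h, within an estimated range of 2.5 h to 12 h.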

Compound 3, half-life: > 5 h
Compound 3: no number, only a limit; the forecaster's own chance of this, stated with the estimate: 65%; the middle value does not contradict the limit.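

No step can be read among compound 1, compound 2 and compound 3, since all three results in this assay are limits, not numbers: the limit of > 5 h in this assay, at which 3 of the 3 values shown sit. On these data alone, how long each compound actually lasts, and whether their differing chains change it at all, remains open.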